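Fluoro to Methyl on the Sulfonyl Aryl Ring

The source may report more compounds than this note shows. Statements on the series, on what has been measured and on what is new or still open speak of the compounds shown alone.

Measured compounds:
compound 1, `COc1cccc(-c2c(S(=O)(=O)c3ccc(C)c(F)c3)cnc3c(F)cccc23)c1`, 4.02 mL/min
compound 2, `O=S(=O)(c1ccc(F)c(F)c1)c1cnc2c(F)cccc2c1-c1cccc(F)c1`, 1.28 mL/min

In an ADME assay on microsomes from liver (Homo sapiens) for metabolic stability, tested at 2.5 uM (a lower number here means slower removal, a higher number faster removal of the compound), compound 2 gives 1.28 mL/min, the lowest of the two numbers recorded so far; compound 1 gives 4.02 mL/min, a gap that lies beyond the usual scatter. Compound 3, `Cc1ccc(S(=O)(=O)c2cnc3c(F)cccc3c2-c2cccc(F)c2)cc1F`, has not yet been measured. It differs from compound 2 in one place: methyl in place of fluoro on an aromatic carbon. The two measured compounds differ in two places at once, so no single step can be read from them. Compound 1 does carry the same 3-fluoro-4-methylphenyl group as compound 3, and its value is the higher one, which supports expecting a moderate rise in this assay, though the methoxy group on compound 1 is not present in compound 3 and keeps that reading uncertain. For compound 3 the expected step is a 1.8-fold higher number from compound 2 to compound 3 (0.25 log units; within the scatter), and the estimated value is 2.3 mL/min, with a range from 1.1 mL/min to 4.6 mL/min.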

Compound 3, intrinsic clearance in a liver preparation (reported as CLH), per the amount of preparation that the assay uses: 3.92 mL/min
Compound 3: middle estimate off by 1.7-fold (0.23 log units), on the low side, within the range that was stated.
By their numbers in this assay, from the lowest: compound 2; then compounds 3 and 1 (each within the scatter of the next).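

In this assay, going by these compounds alone, methyl in place of fluoro, ortho to a fluoro group and para to a large group, gives a 3.1-fold higher number from compound 2 to compound 3 (0.49 log units; beyond the scatter), the first change at this position that can be read on its own, and it lies beyond the scatter. With the 3-fluoro-4-methylphenyl group held constant, fluoro in place of methoxy on an aromatic carbon gives a 1.0-fold lower number from compound 1 to compound 3 (0.01 log units; within the scatter), which lies within the scatter, so this assay does not separate those two compounds. Nothing available here accounts for the rise that comes with the methyl group.

As far as these compounds go, it remains open whether a chloro, ethyl, trifluoromethyl or nitrile group at this position would sit with the fluoro compound or the methyl compound. From the compounds shown here alone, whether the step from fluoro to methyl would be of similar size with the methoxy group in place also remains open.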